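Swapping piperidin-1-yl for (2-hydroxyethyl)amino on the amide

The source may hold more compounds than are shown below. What is called first, only, known or untested is meant among the compounds shown, and "the series" means these compounds.

Compound 2 `COc1cc2c(cc1OC)C(CC(=O)N1CCCCC1)CC2` stands highest of the two numbers measured in a functional assay on the whole organism (strain Wistar) for inhibition, with Rattus norvegicus as the target, read by paw edema, with stated times of 60 min and 24 h, at a dose of 100 mg/kg by the oral route; a lower number here means less inhibition, a higher number more inhibition at the dose given (going by the name of the read-out): compound 2 gives 40%. Within the data shown here, its only measured neighbour is compound 1 `COc1cc2c(cc1OC)C(CC(=O)O)CC2`, which in this assay gives 26.7%, and the single measured step runs a number 13.3 percentage points higher from compound 1 to compound 2 (beyond the scatter). Compound 3 `COc1cc2c(cc1OC)C(CC(=O)NCCO)CC2` has not yet been measured. It differs from compound 2 in one place: (2-hydroxyethyl)amino in place of piperidin-1-yl on a carbonyl carbon. The step from compound 1 to compound 2 bears on this change only loosely: there, hydroxy gave way to piperidin-1-yl on the same carbonyl carbon, whereas here one group on that carbonyl carbon gives way to another. Among the measured compounds shown here, no measured step shows the effect of a (2-hydroxyethyl)amino group. Compound 3 is therefore expected to sit between the two measured numbers, a step of a number 7 percentage points lower from compound 2 to compound 3 (within the scatter) that stays within the scatter. The estimate for compound 3 in this assay is 33%, expected to fall between 18% and 48%.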

Compound 3, a percentage reported as inhibition, in the whole organism at one dose (the size of the read-out at that dose, not a potency): 13.3%
The estimate for compound 3 lay 19.7 percentage points above the measured number, outside the stated range (below it).
By their numbers in this assay, from the lowest: compound 3; then compound 1; then compound 2.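

In this assay, placing (2-hydroxyethyl)amino on the carbonyl carbon gives a number 26.7 percentage points lower from compound 2 to compound 3 (beyond the scatter), and set against the hydroxy group it gives a number 13.4 percentage points lower from compound 1 to compound 3 (beyond the scatter). An amide at this carbonyl carbon therefore does not raise the number by itself: the piperidin-1-yl amide, compound 2, stands above the acid, compound 1, while the (2-hydroxyethyl)amino amide, compound 3, stands below it, so the outcome depends on the group attached and can go in either direction. Nothing available explains this split between the two amides.

The compounds leave open whether the fall in compound 3 goes with the terminal hydroxy group of its chain or with the loss of the piperidine ring. An ethylamino group, which keeps the chain without the hydroxy group, and a morpholin-4-yl group, which keeps a ring and adds an oxygen, remain untested among the compounds shown here.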